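The compounds below may be only part of what the source reports. "The series", "measured", "known", "first", "only" and "open" are said of these compounds alone.

Working notes on the series. Compound 1 `COc1ccccc1CNc1nc2c(N)ncnc2n1[C@@H]1O[C@H](CO)[C@@H](O)[C@H]1O` is measured in an assay on COS-7 cells for inhibition of sodium/nucleoside cotransporter 2 (Homo sapiens), read by scintillation counting, in the presence of a further agent that is not named here (on this read-out higher numbers stand for weaker inhibition and lower numbers for stronger inhibition), and reaches only the limit of the assay, > 100000 nM, not a number. Compound 2 `Nc1ncnc2c1ncn2[C@@H]1O[C@H](COC(=O)NCc2ccccc2)[C@@H](O)[C@H]1O` likewise gives only the limit > 100000 nM in this assay. Compound 1 thus stands at the limit of > 100000 nM in this assay, at which 2 of the 2 values shown sit. The next compound is compound 3 `Nc1ncnc2c1nc(NCc1ccc(Cl)cc1)n2[C@@H]1O[C@H](CO)[C@@H](O)[C@H]1O`, which carries the change (4-chlorophenyl in place of 2-methoxyphenyl on a saturated chain carbon bound to a nitrogen on an aromatic ring). No step between measured compounds is known, and both shown values sit at the limit, so no change beyond the scatter is expected for the step of a number no higher from compound 1 to compound 3 (the limit leaves the size open). Compound 3 is estimated at 100000 nM, in the range 30000 nM to 500000 nM.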

Compound 3, half-maximal inhibitory concentration: 11000 nM
Compound 3: the middle estimate sits 9.1-fold (0.96 log units) above what was measured; measured number outside the range, below it.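

Putting 4-chlorophenyl in place of 2-methoxyphenyl on a saturated chain carbon bound to a nitrogen on an aromatic ring gives an at least 9.0-fold lower number from compound 1 to compound 3 (0.95 log units; beyond the scatter) in this assay and shows that this place responds to the group it carries. The earlier compounds shown here could not show this, as their values gave no order: the limit of > 100000 nM in this assay, at which 2 of the 3 values shown sit. On these data alone, compound 1 holds only a limit, so the full size of the step stays open.

Whether the chlorine or the ring position accounts for the step remains unresolved. So does the outcome with 2-chlorophenyl, 4-methoxyphenyl or a longer chain such as phenethyl.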